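The source may hold more compounds than are shown below. What is called first, only, known or untested is meant among the compounds shown, and "the series" means these compounds.

Compound 1 `COc1cc(-c2nn(-c3cccc(NC(=O)Nc4ccc(Cl)c(Cl)c4)c3)cc2-c2ccncc2)ccc1Cl` gives 1430 nM in a functional assay on SK-MEL-28 cells (Homo sapiens) for inhibition, read by sulforhodamine B assay, with a stated time of 48 h (on this read-out lower numbers stand for stronger inhibition of growth and higher numbers for weaker inhibition of growth), and stands second highest of the three numbers recorded. Among the compounds with values here, compound 2 `O=C(Nc1cccc(-n2cc(-c3ccncc3)c(-c3ccc(Cl)c(O)c3)n2)c1)Nc1ccc(Cl)c(Cl)c1` gives 1460 nM in this assay; the step of a 1.0-fold higher number from compound 1 to compound 2 (0.01 log units; within the scatter) is the only single-place step in the set, and it alters a different part of the molecule from the one considered here. Compound 3 `O=C(Nc1cccc(-n2cc(-c3ccncc3)c(-c3ccc(Cl)c(O)c3)n2)c1)Nc1cc(C(F)(F)F)cc(C(F)(F)F)c1` gives 796 nM in this assay; its gap to compound 1 is within the scatter, so the three compounds are not separated on this read-out.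

Compound 4 `COc1cc(-c2nn(-c3cccc(NC(=O)Nc4ccc(Cl)c(C(F)(F)F)c4)c3)cc2-c2ccncc2)ccc1Cl` differs from compound 1 by trifluoromethyl in place of chloro on an aromatic carbon. Within the data shown here, no measured step covers this change. The nearest comparison is compound 2 against compound 3, where the 3,4-dichlorophenyl end is replaced by a ring carrying two trifluoromethyl groups; compound 2 shows 1460 nM and compound 3 shows 796 nM, a gap inside the scatter. That pair alters more than one position and is not a single-place step, so it offers only a loose hint, and the hint is of no movement beyond the scatter. The step of a 1.3-fold lower number from compound 1 to compound 4 (0.11 log units; within the scatter) is therefore expected to be small. The estimate for compound 4 is 1100 nM, with a range from 450 nM to 2800 nM.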

Compound 4, concentration for 50% growth inhibition: 1200 nM
Estimate against measurement, compound 4: 1.1-fold (0.04 log units) below; the range from low to high includes it.
By their numbers in this assay, from the lowest: compounds 3, 4, 1 and 2 (each within the scatter of the next).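

In this assay, within the data shown here, the change from 3,4-dichlorophenyl to 4-chloro-3-(trifluoromethyl)phenyl gives the first single-place reading at this end of the molecule: a 1.2-fold lower number from compound 1 to compound 4 (0.08 log units; within the scatter). Among these compounds, the only earlier step, a 1.0-fold higher number from compound 1 to compound 2 (0.01 log units; within the scatter), concerned hydrogen in place of methyl on an oxygen on an aromatic ring and so said nothing about this position. Here, trifluoromethyl in place of chloro on an aromatic carbon brings 4 heavy atoms where 1 left, with no change in the count of hydrogen-bond donors or acceptors, and the two compounds are not separated on this read-out. No supporting measurement is available to explain this result.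

Whether an amine, a carboxylic acid or a longer chain on this aromatic carbon would move the number beyond the scatter remains open, since the compounds shown compare only chloro and trifluoromethyl here in a single-place step. Among the compounds shown here, this change is also seen only with the methyl on oxygen of compound 1 in place, so its effect with the hydrogen of compound 2 at that oxygen remains unknown.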